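Acetamido in place of chloro: an estimate for compound 4

The compounds below may be only part of what the source reports. "The series", "measured", "known", "first", "only" and "open" are said of these compounds alone.

Compound 1 `N#CC1=C(N)Oc2c(c3nc4ccccc4nc3c3ccccc23)C12C(=O)N(Cc1cnnn1-c1cccc(S(N)(=O)=O)c1)c1ccccc12`: in a functional assay on HCT-116 cells (Homo sapiens) for antiproliferative activity, read by MTT assay, with a stated time of 48 h (a lower number here means a stronger inhibitor, a higher number a weaker inhibitor), compound 1 gives 11300 nM.
Compound 2 `CCc1ccccc1-n1nncc1CN1C(=O)C2(C(C#N)=C(N)Oc3c(N)cc4nc5ccccc5nc4c32)c2ccccc21`: in this assay compound 2 gives 10300 nM.
Compound 3 `N#CC1=C(N)Oc2c(N)cc3nc4ccccc4nc3c2C12C(=O)N(Cc1cnnn1-c1ccc(Cl)cc1)c1ccccc12`: in this assay compound 3 reaches only the limit of the assay, > 50000 nM, and no number is known for it.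

Compound 3 therefore stands at the edge of what the assay reports; how far beyond that edge it lies is open. Within the data shown here, its one measured neighbour is compound 2, and the step of an at least 4.8-fold higher number from compound 2 to compound 3 (0.68 log units; beyond the scatter) shows that exchanging the group on the aromatic nitrogen can move the result strongly. Compound 1 carries a different core and a different group there, so its value can only be set beside the others, not read as a step.

Compound 4 `CC(=O)Nc1ccc(-n2nncc2CN2C(=O)C3(C(C#N)=C(N)Oc4c(N)cc5nc6ccccc6nc5c43)c3ccccc32)cc1` differs from compound 3 in one place: acetamido in place of chloro on an aromatic carbon. Among the measured compounds shown here, no measured step changes this position, so the single measured step gives only a rough sense of how much such exchanges matter. The expected step of an at least 1.6-fold lower number from compound 3 to compound 4 (0.22 log units; that floor lies within the scatter) is set with wide uncertainty, and compound 4 is estimated at 30000 nM, within a range from 8000 nM to 120000 nM.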

Compound 4, half-maximal inhibitory concentration: > 50000 nM
Compound 4 ended at the assay's limit; the forecaster's own chance of this, stated with the estimate: 45%; middle value at least 1.6-fold (0.22 log units) from the limit.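

Compound 3 and compound 4 both sit at a limit of this assay, so the step from chloro to acetamido on this ring cannot be read: the limit of > 50000 nM in this assay, at which 2 of the 4 values shown sit.

What compound 4 adds is a second group at this place, para to a large group, that ends at the limit, and the exchange of 2-ethylphenyl for 4-acetamidophenyl gives an at least 4.8-fold higher number from compound 2 to compound 4 (0.68 log units; beyond the scatter). Acetamido brings a hydrogen-bond donor and a hydrogen-bond acceptor that chloro lacks, yet the result stays outside the range the assay reports.

On these data alone, how far beyond the limit compound 3 and compound 4 each lie remains open, and so does their order. Also open, as far as these compounds go, is whether an amine or a carboxylic acid at this place would give a readable value.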